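The source may report more compounds than this note shows. Statements on the series, on what has been measured and on what is new or still open speak of the compounds shown alone.

Three compounds in this study share one core and differ only in the group attached to the amide-type nitrogen of that core. Compound 1 `O=C1CN(S(=O)(=O)c2cc3ccc(Cl)cc3s2)CCN1Cc1cc2[nH]cccc-2n1` was tested in an assay on isolated protein for binding affinity to serine protease 1 (Homo sapiens); on this read-out lower numbers stand for stronger inhibition and higher numbers for weaker inhibition. In this assay compound 1 reaches only the limit of > 2900 nM, a boundary of the method rather than a number. Compound 2 `O=C1CN(S(=O)(=O)c2cc3ccc(Cl)cc3s2)CCN1Cc1cc2cc[nH]cc-2n1` likewise gives in this assay only the limit > 2900 nM. The change between them, a step that the two limits leave unreadable from compound 1 to compound 2, cannot be sized. Compound 3 `COC(=O)Cn1c(CN2CCN(S(=O)(=O)c3cc4ccc(Cl)cc4s3)CC2=O)cc2cnccc21`, which carries a (methoxycarbonyl)methyl group, also returns in this assay only the limit > 2900 nM. Going by the values given here, all three results sit at the same boundary (the limit of > 2900 nM in this assay, at which 3 of the 3 values shown sit), and no measured step in this set has a readable size.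

Compound 4 `O=C(O)Cn1c(CN2CCN(S(=O)(=O)c3cc4ccc(Cl)cc4s3)CC2=O)cc2cnccc21` differs from compound 3 by hydrogen in place of methyl on an oxygen next to a carbonyl group. Among the compounds with values here, every value so far is a limit; no measured step bears on this change, and no direction can be read from the data. The step from compound 3 to compound 4 is expected to be a step that the limit leaves unreadable from compound 3 to compound 4, with a large chance that the assay again reports only a limit. Compound 4 is estimated at 5000 nM, with a range from 1500 nM to 20000 nM.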

Compound 4, inhibition constant: > 2900 nM
Compound 4 gave a limit, no number; the forecaster's own chance of this, stated with the estimate: 80%; the middle value lies beyond the limit too.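

Going by these compounds alone, compound 3 and compound 4 both return only a limit in this assay, so the change from (methoxycarbonyl)methyl to carboxymethyl gives no step of readable size. The compounds shown leave open how strong the inhibition by any of them really is, and whether this change alters it at all, because every result sits at one boundary: the limit of > 2900 nM in this assay, at which 4 of the 4 values shown sit.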